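Acid dissociation across a quinoline-free description: three measured, one pending

The compounds below may be only part of what the source reports. "The series", "measured", "known", "first", "only" and "open" are said of these compounds alone.

Measured compounds and values in a physicochemical assay for acid dissociation:
compound 1, `CC(C)(C)c1ccc(Oc2ccc3c(NCCCNCc4ccco4)ccnc3c2)cc1`, 9.28
compound 2, `Fc1ccc(Oc2ccc3c(NCCCNCc4ccco4)ccnc3c2)cc1`, 9.28
compound 3, `COc1cccc(CNCCCNc2ccnc3cc(Oc4ccc(F)cc4)ccc23)c1O`, 9.28

Compound 2 stands level with compounds 1 and 3 at the digits shown; within the scatter nothing separates the three. The step from compound 1 to compound 2, fluoro in place of tert-butyl on an aromatic carbon, gave no change at the digits printed from compound 1 to compound 2 (within the scatter). The step from compound 2 to compound 3, 2-hydroxy-3-methoxyphenyl in place of furan-2-yl on a saturated chain carbon bound to an amine nitrogen, gave no change at the digits printed from compound 2 to compound 3 (within the scatter).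

Compound 4, `c1coc(CNCCCNc2ccnc3cc(CC4CCCCC4)ccc23)c1`, is not yet measured. Its difference from compound 2 is cyclohexylmethyl in place of 4-fluorophenoxy on an aromatic carbon. Both measured steps bear on it only loosely: one changed a substituent on an aromatic carbon, the other a group on the chain, and neither moved this assay beyond the scatter. Within the data shown here, no measured step has exchanged a group of this size on the shared core, so the expectation rests on the two flat steps alone. The expected step from compound 2 to compound 4 is no change at the digits printed from compound 2 to compound 4 (within the scatter), that is, none beyond the scatter. Compound 4 is therefore estimated at 9.28, in the range 8.95 to 9.6.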

Compound 4, acid dissociation constant: 9.47
Compound 4: the middle estimate sits 0.19 log units below what was measured; the measured number falls inside the stated range.
By their numbers in this assay, from the lowest: compounds 1, 2, 3 and 4 (each within the scatter of the next).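

In this assay, cyclohexylmethyl in place of 4-fluorophenoxy on an aromatic carbon gives a number 0.19 log units higher from compound 2 to compound 4 (within the scatter). Unlike the step from tert-butyl to fluoro, which kept the phenoxy unit in place, this change removes the whole group, including its oxygen and its six-membered aromatic ring, and puts a non-aromatic ring of carbon only at this position, yet the step stays within the scatter. No measurement is at hand that would explain the reading of this step.

Still open, going by these compounds, is whether an amine or a carboxylic acid at this position, or a longer chain in place of cyclohexylmethyl, would also stay within the scatter in this assay. Also open, on these data alone, is whether cyclohexylmethyl gives the same reading when 2-hydroxy-3-methoxyphenyl replaces furan-2-yl on the chain.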